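The compounds below may be only part of what the source reports. "The series", "measured", "known", "first", "only" and "open" are said of these compounds alone.

Measured in a functional assay on T47D cells (Homo sapiens) for inhibition; a lower number here means a stronger inhibitor of growth, a higher number a weaker inhibitor of growth:
- Compound 1 `C=C1C(=O)O[C@H]2[C@H]1CC/C(COC(=O)N1CCC(F)(F)CC1)=C\CC[C@@]1(C)O[C@@H]21`: 3070 nM
- Compound 2 `C=C1C(=O)O[C@H]2[C@H]1CC/C(COC(=O)NCCN1CCCC1)=C\CC[C@@]1(C)O[C@@H]21`: 4860 nM

For the measured compounds named here, compound 2 cannot be separated from the only other measured compound, as the single available step shows: a 1.6-fold higher number from compound 1 to compound 2 (0.20 log units; within the scatter). Compound 3 `C=C1C(=O)O[C@H]2[C@H]1CC/C(COC(=O)Nc1n[nH]c(SC)n1)=C\CC[C@@]1(C)O[C@@H]21` keeps the shared core and changes one group on an amide-type nitrogen: 5-(methylsulfanyl)-1H-1,2,4-triazol-3-yl in place of 2-(pyrrolidin-1-yl)ethyl on an amide-type nitrogen. Going by the values given here, the one measured step bears on this change only indirectly, as it also exchanges a group on the same carbonyl carbon. In that step, a large change of group left the number within the scatter. However, neither measured compound carries an aromatic ring at this place, so the evidence is thin and the range must stay wide. No shift beyond the scatter is therefore expected, and the estimated change is a 1.2-fold lower number from compound 2 to compound 3 (0.08 log units; within the scatter). In this assay, the expected value for compound 3 is 4000 nM, with an estimated range of 1500 nM to 10000 nM.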

Compound 3, concentration for 50% growth inhibition: 2230 nM
For compound 3 the middle estimate is 1.8-fold (0.25 log units) above the measured one; the range from low to high includes it.
By their numbers in this assay, from the lowest: compounds 3, 1 and 2 (each within the scatter of the next, the first and the last beyond it).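

In this assay, for the compounds shown here, the exchange of 2-(pyrrolidin-1-yl)ethyl for 5-(methylsulfanyl)-1H-1,2,4-triazol-3-yl on an amide-type nitrogen gives the first step at this place that lies beyond the scatter, though a modest one: a 2.2-fold lower number from compound 2 to compound 3 (0.34 log units; beyond the scatter). Set against 4,4-difluoropiperidin-1-yl on a carbonyl carbon, the (5-(methylsulfanyl)-1H-1,2,4-triazol-3-yl)amino group stays within the scatter, a 1.4-fold lower number from compound 1 to compound 3 (0.14 log units; within the scatter), so it separates compound 3 from compound 2 only and not from compound 1. Nothing at hand accounts for this shift.

From the compounds shown here alone, it remains open how this assay would respond to an amino group or a carboxylic acid in place of the methylsulfanyl group on the triazole ring. Also open, going by these compounds, is whether a phenyl ring or a longer chain on the amide-type nitrogen would move the number at all.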